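Triazole-linked dienone coumarin series: growth inhibition notes

The source may report more compounds than this note shows. Statements on the series, on what has been measured and on what is new or still open speak of the compounds shown alone.

Measured in a functional assay on HCT-116 cells (Homo sapiens) for inhibition, read by sulforhodamine B assay, with a stated time of 48 h, tested at 50 uM; on this read-out higher numbers stand for more inhibition of growth at the one concentration tested and lower numbers for less inhibition of growth:
compound 1 `COc1cc(/C=C/C(=O)/C=C/c2ccccc2)ccc1OCc1cn(CCCCCOc2cc(=O)oc3ccccc23)nn1`: 24%
compound 2 `COc1cc(/C=C/C(=O)/C=C/c2cc(OC)c(OC)c(OC)c2)ccc1OCc1cn(CCCCCOc2cc(=O)oc3ccccc23)nn1`: 53%
compound 3 `COc1cc(/C=C/C(=O)/C=C/c2ccccc2)ccc1OCc1cn(CCCOc2cc(=O)oc3ccccc23)nn1`: 45%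

Compound 2 differs from compound 1 by 3,4,5-trimethoxyphenyl in place of phenyl on a double-bonded chain carbon bound to a double-bonded chain carbon. This change gives a number 29 percentage points higher from compound 1 to compound 2 (beyond the scatter). Compound 4 `COc1cc(/C=C/C(=O)/C=C/c2cc(OC)c(OC)c(OC)c2)ccc1OCc1cn(CCCOc2cc(=O)oc3ccccc23)nn1` is not yet measured; it differs from compound 3 by 3,4,5-trimethoxyphenyl in place of phenyl on a double-bonded chain carbon bound to a double-bonded chain carbon, the same change at the same place, occurring twice among these compounds. The difference between the cores of compound 1 and compound 3 is not broken down here; their values alone show compound 3 higher than compound 1, while compound 3 and compound 2 lie within the scatter of each other. For compound 4 a step of the earlier size is expected, a number 25 percentage points higher from compound 3 to compound 4 (beyond the scatter), resting on the step of a number 29 percentage points higher from compound 1 to compound 2 (beyond the scatter) seen once. Compound 4 is accordingly estimated at 70%, expected between 52% and 88%.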

Compound 4, percent growth inhibition at one concentration: 76%
For compound 4 the middle estimate is 6 percentage points below the measured one; measured number inside the range.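

In this assay, 3,4,5-trimethoxyphenyl in place of phenyl gives a number 31 percentage points higher from compound 3 to compound 4 (beyond the scatter), and the step carries over from the core of compound 1 to the core of compound 3 at a matching size: the same change on two cores in this assay, a number 29 percentage points higher (beyond the scatter) from compound 1 to compound 2 and a number 31 percentage points higher (beyond the scatter) from compound 3 to compound 4, 2 percentage points apart, within the scatter of two such steps. On these two cores, the earlier step was a usable guide to the size of the new one. For the compounds shown here, this rests on only two pairs read at one concentration, and it does not show that the step would hold on any other core or at other concentrations.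

Still open, going by these compounds, is what a phenyl bearing a single methoxy group, or an amine, would give at this place on the core of compound 3. On these data alone, whether the step persists with a longer chain also remains open.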